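A few compounds are considered here, and "the series" means these few. Any claim that something is new, unique, unknown or untested is made for them only; others in the source may bear on it.

Measured so far:
Compound 1 `OB1OCc2ccc(-n3cc(Sc4ccc(O)cc4)c4ccccc43)cc21` was tested in an ADME assay on L929 cells (Mus musculus) for cytotoxicity, read by resazurin assay, with a stated time of 72 h (on this read-out higher numbers stand for weaker inhibition and lower numbers for stronger inhibition), and, as compound 1, gave only the limit > 10 ug/mL rather than a number.
Compound 2 `OB1OCc2ccc(-n3cc(Sc4ccc(Cl)cc4)c4ccccc43)cc21` in this assay likewise gave only the limit > 10 ug/mL, not a number.

Compound 2 therefore stands where everything measured here stands: the limit of > 10 ug/mL in this assay, at which 2 of the 2 values shown sit. Among the measured compounds shown here, the one measured step, a step that the two limits leave unreadable from compound 1 to compound 2, cannot be read, since both ends are limits and the true size of any difference between the two compounds is hidden.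

The next change leads to compound 3 `OB1OCc2ccc(-n3cc(Sc4ccccc4O)c4ccccc43)cc21`. It is 2-hydroxyphenyl in place of 4-chlorophenyl on a sulfur. For the measured compounds named here, no measured step speaks to this change directly; the only step in hand, from a hydroxy-bearing ring to a chloro-bearing ring, gave no readable size. With two limits and no visible movement, the expectation for compound 3 in this assay is a step that the limit leaves unreadable from compound 2 to compound 3 that stays within the scatter, and most likely a limit again. The estimate for compound 3 is 15 ug/mL, with a range from 7 ug/mL to 40 ug/mL.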

Compound 3, half-maximal inhibitory concentration: > 10 ug/mL
Compound 3 gave a limit, no number; the forecaster's own chance of this, stated with the estimate: 80%; the middle value does not contradict the limit.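

Compound 3, like compound 1 and compound 2, gives only a limit and not a number in this assay, so the steps from compound 2 and from compound 1 to compound 3 cannot be read: the limit of > 10 ug/mL in this assay, at which 3 of the 3 values shown sit.

The compounds shown leave open how strongly each one acts on these cells, and whether 2-hydroxyphenyl in place of 4-chlorophenyl on a sulfur changes that at all.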